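The compounds below may be only part of what the source reports. "The series", "measured", "known", "first", "only" and "open" are said of these compounds alone.

Compound 1 `CCOC(=O)c1nn(-c2ccccc2)c(-c2ccc(F)cc2)c1CNC(C)(C)C`: > 632000 nM; > 579000 nM (2 entries)
Compound 2 `CCOC(=O)c1nn(-c2ccc(Cl)cc2)c(-c2ccc(OC)cc2)c1CNC(C)(C)C`: 431000 nM; > 523000 nM (2 entries)
Compound 3 `CC(C)(C)NCc1c(C(=O)O)nn(-c2ccccc2)c1-c1ccc(F)cc1`: > 680000 nM

All three compounds were tested in a functional assay on U-251 cells (Homo sapiens) for inhibition, read by sulforhodamine B assay, with a stated time of 48 h; on this read-out lower numbers stand for stronger inhibition of growth and higher numbers for weaker inhibition of growth. Compound 3 has no exact value, only a limit of > 680000 nM. Compound 1 likewise gives only limits, > 632000 nM; > 579000 nM (2 entries). Compound 2 gives 431000 nM; > 523000 nM (2 entries).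

Compound 4 `COc1ccc(-c2c(CNC(C)(C)C)c(C(=O)O)nn2-c2ccccc2)cc1` has not yet been measured. It differs from compound 3 in one place, with methoxy in place of fluoro on an aromatic carbon, para to a large group, so that 4-fluorophenyl becomes 4-methoxyphenyl (methoxy in place of fluoro on an aromatic carbon).

For the measured compounds named here, no two measured compounds differ in just one place, so this change has no direct measured precedent. Compound 2 also carries a 4-methoxyphenyl group and gives 431000 nM; > 523000 nM (2 entries), but it differs from compound 3 in more than this one group, which makes it only a loose guide. In this assay, the expectation is therefore no step beyond the scatter, in either direction. The expected change is an at least 1.0-fold lower number from compound 3 to compound 4 (0.04 log units; that floor lies within the scatter). A limit rather than an exact number is the likely result for compound 4. For compound 4 the estimated value is 620000 nM, with an expected range of 400000 nM to 700000 nM.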

Compound 4, concentration for 50% growth inhibition: > 659000 nM
Compound 4 gave a limit, no number; the forecaster's own chance of this, stated with the estimate: 80%; at least 1.0-fold (0.02 log units) between middle value and limit.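

In this assay, for the compounds shown here, compound 3 and compound 4 each gave only a limit rather than an exact number, and no step between them can be read. The compounds shown leave open whether changing 4-fluorophenyl to 4-methoxyphenyl alters growth inhibition at all, and in which direction any such change would run.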